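A few compounds are considered here, and "the series" means these few. Any claim that something is new, unique, unknown or untested is made for them only; others in the source may bear on it.

Measured so far: compound 1 `Cc1cc2oc(N)c(/C=N/NCCO)c(=O)c2cc1C` with 23500 nM; compound 2 `O=c1c(/C=N/Nc2cc(Cl)ccc2Cl)coc2ccccc12` with 265000 nM.

In a functional assay on HL-60 cells (Homo sapiens) for cytotoxicity, read by MTT assay, with a stated time of 48 h (on this read-out higher numbers stand for weaker inhibition and lower numbers for stronger inhibition), compound 2 gives 265000 nM, the higher of the two numbers and beyond the usual scatter from compound 1, which gives 23500 nM. Compound 3 `Nc1oc2ccccc2c(=O)c1/C=N/Nc1cc(Cl)ccc1Cl` differs from compound 2 by amino in place of hydrogen on an aromatic carbon. For the measured compounds named here, no step of exactly this kind has been measured. Compound 1 also carries an amino group on its core and shows the lower number, but it differs in other places as well, so this is only a loose hint. A moderate step downward is expected, a 3.8-fold lower number from compound 2 to compound 3 (0.58 log units; beyond the scatter). Compound 3 is estimated at 70000 nM, with a range from 15000 nM to 300000 nM.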

Compound 3, half-maximal inhibitory concentration: > 1000000 nM
Compound 3: a limit, no number; the forecaster's own chance of this, stated with the estimate: 15%; at least 14-fold (1.15 log units) between middle value and limit.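

In this assay, amino in place of hydrogen on this aromatic carbon, next to the ring oxygen, weakens inhibition rather than strengthening it, with an at least 3.7-fold higher number from compound 2 to compound 3 (0.57 log units; beyond the scatter). Compound 3 gives a limit, not a number: the limit of > 1000000 nM in this assay, at which 1 of the 3 values shown sits.

On these data alone, the true size of this step therefore stays unknown, and only its direction and smallest size can be read. The compounds shown also leave open whether a methyl group or a hydroxyl group at this position would shift the number in the same direction as amino.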